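The source may report more compounds than this note shows. Statements on the series, on what has been measured and on what is new or still open speak of the compounds shown alone.

Compound 3 `Cn1ccc2c(Oc3ccc(NC(=O)c4nn(-c5ccc(Cl)c(C(F)(F)F)c5)ccc4=O)cc3)ccnc21` is where this step starts. In a functional assay on PC-3 cells (Homo sapiens) for cytotoxicity, read by MTT assay, with a stated time of 72 h (a higher number here means a weaker inhibitor, a lower number a stronger inhibitor), compound 3 gives 10300 nM, the highest of the two numbers shown. Compound 1 `O=C(Nc1ccc(Oc2ccnc3[nH]ccc23)cc1)c1nn(-c2ccc(Cl)c(C(F)(F)F)c2)ccc1=O` has hydrogen where compound 3 has methyl on an aromatic nitrogen. In this assay compound 1 gives 4630 nM, so that a 2.2-fold higher number from compound 1 to compound 3 (0.35 log units; beyond the scatter). Compound 2 `Cn1ccc2c(Oc3ccc(NC(=O)c4nn(-c5ccc(Cl)cc5)ccc4=O)cc3)ccnc21` reaches only a limit in this assay, > 60000 nM. Adding trifluoromethyl gives an at least 5.8-fold lower number from compound 2 to compound 3 (0.76 log units; beyond the scatter). Compound 4 `Cn1ccc2c(Oc3ccc(NC(=O)c4nn(-c5ccc(Cl)c(C(F)(F)F)c5)ccc4=O)cc3F)ccnc21` differs from compound 3 by fluoro in place of hydrogen on an aromatic carbon. Neither measured step is this change; the nearest, an at least 5.8-fold lower number from compound 2 to compound 3 (0.76 log units; beyond the scatter), involved a different group on a different ring. A small step in this assay is therefore expected, probably within the scatter and leaning lower, an estimated 1.5-fold lower number from compound 3 to compound 4 (0.17 log units; within the scatter). Compound 4 is estimated at 7000 nM, between 2500 nM and 20000 nM.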

Compound 4, half-maximal inhibitory concentration: 20900 nM
Compound 4: the middle estimate sits 3.0-fold (0.48 log units) below what was measured, outside the stated range (above it).
By their numbers in this assay, from the lowest: compound 1; then compound 3; then compound 4. At a limit, above all of these: compound 2.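

Within the data shown here, on the ring of carbon only that carries the amide nitrogen, where no earlier step had touched the shared core, this assay responds to a single fluoro ortho to a large group and meta to a large group, with a 2.0-fold higher number from compound 3 to compound 4 (0.31 log units; beyond the scatter) as a modest change. This step runs in the same direction as a 2.2-fold higher number from compound 1 to compound 3 (0.35 log units; beyond the scatter) and against an at least 5.8-fold lower number from compound 2 to compound 3 (0.76 log units; beyond the scatter). No measurement shown here accounts for the rise.

As far as these compounds go, whether a methoxy or an amine on this same aromatic carbon would move the number the same way stays open.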